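This account rests on a few compounds, and the source may have more. Where it says the series, first, only, none or still open, it means among the compounds named here.

The measured compounds and their numbers in a functional assay on the whole organism (strain Wistar) for inhibition, with Rattus norvegicus as the target, read by paw edema, with stated times of 30 min and 3 h, at a dose of 100 mg/kg by the oral route; on this read-out higher numbers stand for more inhibition at the one dose given (going by the name of the read-out) and lower numbers for less inhibition:

compound 1, `COc1cc(C(=O)N(C)C)nn1-c1ccccc1`, which gives 47.5%
compound 2, `COc1cc(C(=O)N2CCCC2)nn1-c1ccccc1`, which gives 29.2%
compound 3, `CCCCOc1cc(C(=O)NC)nn1-c1ccccc1`, which gives 65%

Compound 3 stands highest of the three in this assay; compound 1 is nearest to it and compound 2 furthest, both beyond the scatter. The unmeasured compound 4, `CCCCOc1cc(C(=O)NC(C)C)nn1-c1ccccc1`, differs from compound 3 in one place: isopropyl in place of methyl on an amide-type nitrogen. Among the measured compounds shown here, no measured step alters an amide substituent in exactly this way. The step that comes closest is the one on the carbonyl nitrogen of compound 1, where a number 18.3 percentage points lower from compound 1 to compound 2 (beyond the scatter): a larger group on that nitrogen went with a lower number. Compound 4 likewise carries a larger group on the amide-type nitrogen than compound 3, so a step downward of modest size is expected in this assay, though the evidence rests on a single measured pair and a different kind of enlargement. The estimate is therefore a number 11 percentage points lower from compound 3 to compound 4 (beyond the scatter), so that compound 4 is expected to give 54%, with a range from 35% to 72%.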

Compound 4, a percentage reported as inhibition, in the whole organism at one dose (the size of the read-out at that dose, not a potency): 15.8%
Estimate against measurement, compound 4: 38.2 percentage points above; the measured number lies below the stated range.
By their numbers in this assay, from the lowest: compound 4; then compound 2; then compound 1; then compound 3.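

On the amide-type nitrogen of compound 3, a modest enlargement from methyl to isopropyl is far from neutral in this assay: the change goes with a number 49.2 percentage points lower from compound 3 to compound 4 (beyond the scatter). The earlier step at this nitrogen, a number 18.3 percentage points lower from compound 1 to compound 2 (beyond the scatter), concerned only amides with no amide hydrogen and was of modest size, whereas this large step shows that the read-out also depends strongly on the alkyl group when the amide hydrogen is present in both compounds. Nothing available on these compounds accounts for the size of this fall.

The compounds shown leave open whether ethyl on this nitrogen, or a plain carbamoyl with hydrogen in place of methyl, would stand nearer to compound 3 or to compound 4. They also leave open whether isopropyl would go with a similar fall on a core carrying methoxy rather than butoxy.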